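The source may hold more compounds than are shown below. What is called first, only, known or untested is meant among the compounds shown, and "the series" means these compounds.

In an ADME assay on MT2 cells (Homo sapiens) for cytotoxicity, read by XTT assay, with a stated time of 4 days (a lower number here means that less compound is tolerated, a higher number that more compound is tolerated), compound 1 (`Cc1nc(C(NC(=O)C(=O)Nc2ccc(Cl)cc2)C2CCCCN2C)sc1CCO`) gives 88000 nM and compound 2 (`Cc1nc(C(NC(=O)C(=O)Nc2ccc(Cl)c(F)c2)C2CCCCN2)sc1CO`) gives 77800 nM, two values within the usual scatter of each other. Compound 3 (`Cc1nc(C(NC(=O)C(=O)Nc2ccc(Cl)cc2)C2CCCNC2)sc1CCO`) keeps the core of compound 1 but has piperidin-3-yl in place of 1-methylpiperidin-2-yl on a saturated chain carbon bound to an amide-type nitrogen and an aromatic carbon. Among the measured compounds shown here, no measured step shows what this change does, so in this assay a step within the scatter is expected, leaning slightly towards a lower number. The expected step is a 1.4-fold lower number from compound 1 to compound 3 (0.13 log units; within the scatter) and no larger. For compound 3 the estimated value is 65000 nM, with 22000 nM to 170000 nM as its expected range.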

Compound 3, half-maximal cytotoxic concentration: > 78500 nM
Compound 3 ended at the assay's limit; the forecaster's own chance of this, stated with the estimate: 20%; at least 1.2-fold (0.08 log units) between middle value and limit.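

In this assay compound 3 gives > 78500 nM, which is a limit and not a number. Among the compounds shown here, no step between compound 1 and compound 3 can be read from it: the limit of > 78500 nM in this assay, at which 1 of the 3 values shown sits. Going by these compounds, how far piperidin-3-yl in place of 1-methylpiperidin-2-yl moves the half-maximal cytotoxic concentration stays open.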